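Bromo in place of fluoro on the sulfonyl aryl

The compounds below may be only part of what the source reports. "The series", "measured", "known", "first", "only" and "open" are said of these compounds alone.

Measured so far in a functional assay on B16-F10 cells (Mus musculus) for antiproliferative activity, read by ELISA and MTT assay, with a stated time of 48 h; on this read-out lower numbers stand for stronger inhibition and higher numbers for weaker inhibition:
compound 1 `COc1ccc(/C=C/C(=O)NS(=O)(=O)c2ccc(Br)cc2)cc1`, 5.8 ug/mL
compound 2 `Cc1ccc(S(=O)(=O)NC(=O)/C=C/c2ccc(N(C)C)cc2)cc1`, 4.3 ug/mL
compound 3 `CN(C)c1ccc(/C=C/C(=O)NS(=O)(=O)c2ccc(F)cc2)cc1`, 2.3 ug/mL

Compound 3 gives the lowest of the three numbers, though its gap to compound 2 is within the scatter; only compound 1 lies beyond it. Compound 4 `CN(C)c1ccc(/C=C/C(=O)NS(=O)(=O)c2ccc(Br)cc2)cc1` differs from compound 3 by bromo in place of fluoro on an aromatic carbon. Among the measured compounds shown here, the one step that bears on this position is a 1.9-fold lower number from compound 2 to compound 3 (0.27 log units; within the scatter), a change within the scatter. Compound 1 also carries bromo on that ring, but it differs from compound 3 at a second place as well, so its value can only be set beside that of compound 3. On this basis no step beyond the scatter is expected in this assay, and the estimate for compound 4 is 3 ug/mL, between 1.4 ug/mL and 6.5 ug/mL, a step of a 1.3-fold higher number from compound 3 to compound 4 (0.12 log units; within the scatter).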

Compound 4, half-maximal inhibitory concentration: 4.2 ug/mL
For compound 4 the middle estimate is 1.4-fold (0.15 log units) below the measured one; the range from low to high includes it.
By their numbers in this assay, from the lowest: compounds 3, 4, 2 and 1 (each within the scatter of the next, the first and the last beyond it).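

In this assay, a 1.8-fold higher number from compound 3 to compound 4 (0.26 log units; within the scatter), and a 1.0-fold lower number from compound 2 to compound 4 (0.01 log units; within the scatter), so fluoro, bromo and methyl on the sulfonyl aryl ring cannot be told apart while the dimethylamino group stays in place. With bromo held fixed, the other end of the molecule gives the same reading: a 1.4-fold lower number from compound 1 to compound 4 (0.14 log units; within the scatter). No measurement available here explains these values.

On these data alone, whether a carboxylic acid or an amine at this ring position would give a step beyond the scatter remains open. So does whether a nitro group would do so.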